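A few compounds are considered here, and "the series" means these few. Any claim that something is new, unique, unknown or untested is made for them only; others in the source may bear on it.

Compound 1 `O=C(CN1CCCCC1)Nc1ccc2ncnc(Nc3ccc(Cl)cc3)c2c1`: > 100000 nM (a limit)
Compound 2 `CN1CCN(CC(=O)Nc2ccc3ncnc(Nc4ccc(Cl)cc4)c3c2)CC1`: 15000 nM

Going by the values given here, in a functional assay on MCF7 cells (Homo sapiens) for antiproliferative activity, read by MTT assay, with a stated time of 48 h (a higher number here means a weaker inhibitor, a lower number a stronger inhibitor), compound 2 gives 15000 nM, the only actual number so far. Compound 1 reads > 100000 nM, which is a limit of the assay and not a number. Among the compounds with values here, the one measured step, an at least 6.6-fold lower number from compound 1 to compound 2 (0.82 log units; beyond the scatter), lies beyond the scatter, but it concerns 4-methylpiperazin-1-yl in place of piperidin-1-yl on a saturated chain carbon bound to a carbonyl carbon.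

Compound 3 `CN1CCN(CC(=O)Nc2ccc3ncnc(Nc4cccc(Br)c4)c3c2)CC1` keeps that 4-methylpiperazin-1-yl group and changes elsewhere: 3-bromophenyl in place of 4-chlorophenyl on a nitrogen on an aromatic ring. In words, this is 3-bromophenyl in place of 4-chlorophenyl on a nitrogen on an aromatic ring. Within the data shown here, no measured step covers a change at this place, so the step above gives no size to carry over, and the value of compound 2 is the only anchor. No shift beyond the scatter is therefore expected in this assay, though the uncertainty is wide in both directions. The expected change is a 1.3-fold lower number from compound 2 to compound 3 (0.10 log units; within the scatter). For compound 3 the estimated value is 12000 nM, with an expected range from 4000 nM to 40000 nM.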

Compound 3, half-maximal inhibitory concentration: 10000 nM
For compound 3 the middle estimate is 1.2-fold (0.08 log units) above the measured one; low and high end bracket the measured number.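

In this assay, going by these compounds alone, 3-bromophenyl in place of 4-chlorophenyl on a nitrogen on an aromatic ring gives a 1.5-fold lower number from compound 2 to compound 3 (0.18 log units; within the scatter), the first measured step at this place. With the 4-methylpiperazin-1-yl group held constant, this pair does not separate the two aryl groups in this assay, although the change swaps chlorine for bromine and alters the numbered ring position at once, so a single pair cannot speak for either alteration alone. Compound 1 remains a limit of the assay and not a number, so the only step beyond the scatter in the series stays a bound and not a size, and the new step cannot be set against it: the limit of > 100000 nM in this assay, at which 1 of the 3 values shown sits.

Open, on these data alone, is whether 3-chlorophenyl or 4-bromophenyl on the same nitrogen, each altering only one of the two features, would read the same, and whether an unsubstituted phenyl or a methoxy-bearing phenyl would stay in the same range. Also open, as far as these compounds go, is how 3-bromophenyl behaves with piperidin-1-yl on the chain, and whether a morpholine or a longer chain in place of the 4-methylpiperazin-1-yl arrangement would shift the number.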